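Swapping the Aryl Group on a Fused Core

A few compounds are considered here, and "the series" means these few. Any claim that something is new, unique, unknown or untested is made for them only; others in the source may bear on it.

Compound 1, `O=c1[nH]c2[nH]c(-c3ccccc3)cc2c(=O)n1CCN1CCN(c2ccccc2Cl)CC1`: 4.71 nM
Compound 2, `COc1ccccc1-c1cc2c(=O)n(CCN3CCN(c4ccccc4OC)CC3)c(=O)[nH]c2[nH]1`: 1.63 nM

Both compounds were tested in an assay on isolated protein for binding affinity to Adrenergic receptor alpha-1 (Homo sapiens); on this read-out higher numbers stand for weaker inhibition and lower numbers for stronger inhibition. Compound 2 holds the lowest of the two numbers; compound 1 stands at a higher number, beyond the usual scatter. Compound 3, `COc1ccccc1N1CCN(CCn2c(=O)[nH]c3[nH]c(-c4ccc(Cl)cc4)cc3c2=O)CC1`, is not yet measured. It differs from compound 2 in one place: 4-chlorophenyl in place of 2-methoxyphenyl on an aromatic carbon, on a ring that is part of a fused or bridged system of two rings, next to the ring nitrogen. Among the measured compounds shown here, no measured step of this kind exists, so the expectation rests on the two values alone: a small shift toward a higher number, within the scatter, is expected, a 1.8-fold higher number from compound 2 to compound 3 (0.26 log units; within the scatter). Compound 3 is estimated at 3 nM, between 1 nM and 10 nM.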

Compound 3, inhibition constant: 4.08 nM
Compound 3: middle estimate off by 1.4-fold (0.13 log units), on the low side; measured number inside the range.
By their numbers in this assay, from the lowest: compound 2; then compounds 3 and 1 (each within the scatter of the next).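

In this assay, the aromatic carbon of the five-membered ring does respond to a change of aryl group: 4-chlorophenyl in place of 2-methoxyphenyl gives a 2.5-fold higher number from compound 2 to compound 3 (0.40 log units; beyond the scatter) as a modest step beyond the scatter. The binding number stays in the same low range, so this position accepts either group with only a modest shift. Nothing measured here explains the shift.

The swap changes both the substituent and the number in its name, so their shares remain unsettled. 2-Chlorophenyl or 4-methoxyphenyl at this position would separate the two.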